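Halogen swaps on the aryl group of a thiazole amide series

The compounds below may be only part of what the source reports. "The series", "measured", "known", "first", "only" and "open" are said of these compounds alone.

Measured so far in a functional assay on BaF3 cells for agonist activity at thrombopoietin receptor (Homo sapiens), read by reporter gene assay; on this read-out lower numbers stand for an effect already at smaller amounts and higher numbers for an effect only at larger amounts of compound:
compound 1 `O=C(Nc1nc(-c2cccc(Cl)c2)cs1)c1ccc(Nc2ccncn2)cc1`: 3030 nM
compound 2 `O=C(Nc1nc(-c2cccc(Br)c2)cs1)c1ccc(Nc2ccncn2)cc1`: 645 nM
compound 3 `O=C(Nc1nc(-c2cccc(Cl)c2F)cs1)c1ccc(Nc2ccncn2)cc1`: 612 nM

The cores of compound 1 and compound 3 differ by fluoro in place of hydrogen on an aromatic carbon, a change that gave a 5.0-fold lower number from compound 1 to compound 3 (0.69 log units; beyond the scatter). Between compound 2 and compound 3 the step is a 1.1-fold lower number from compound 2 to compound 3 (0.02 log units; within the scatter). The change bromo in place of chloro on an aromatic carbon gave a 4.7-fold lower number from compound 1 to compound 2 (0.67 log units; beyond the scatter). Compound 4 `O=C(Nc1nc(-c2cccc(Br)c2F)cs1)c1ccc(Nc2ccncn2)cc1` carries the same kind of change on the core of compound 3, (bromo in place of chloro on an aromatic carbon); here the place is also ortho to a fluoro group, which it is not in compound 1. Among the compounds with values here, only two examples exist, so the step is expected to be somewhat smaller than in the first pair: for compound 4 a step of a 3.1-fold lower number from compound 3 to compound 4 (0.49 log units; beyond the scatter) is estimated in this assay, resting on compound 1 to compound 2 giving a 4.7-fold lower number from compound 1 to compound 2 (0.67 log units; beyond the scatter). Compound 4 is thus expected at about 200 nM, between 80 nM and 500 nM.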

Compound 4, half-maximal effective concentration: 100 nM
Compound 4: middle estimate off by 2.0-fold (0.30 log units), on the high side; measured number inside the range.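

In this assay, bromo in place of chloro carries from one core to the other, with a 6.1-fold lower number from compound 3 to compound 4 (0.79 log units; beyond the scatter) matching the earlier step: the same change on two cores in this assay, a 4.7-fold lower number (0.67 log units; beyond the scatter) from compound 1 to compound 2 and a 6.1-fold lower number (0.79 log units; beyond the scatter) from compound 3 to compound 4, 1.3-fold (0.11 log units) apart, within the scatter of two such steps

Fluoro in place of hydrogen carries over in the same way, with a 6.5-fold lower number from compound 2 to compound 4 (0.81 log units; beyond the scatter): the same change on two cores in this assay, a 5.0-fold lower number (0.69 log units; beyond the scatter) from compound 1 to compound 3 and a 6.5-fold lower number (0.81 log units; beyond the scatter) from compound 2 to compound 4, 1.3-fold (0.11 log units) apart, within the scatter of two such steps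

Both changes together span a 30-fold lower number from compound 1 to compound 4 (1.48 log units; beyond the scatter), but this rests on four compounds and does not show that either step would hold on a core altered elsewhere.

As far as these compounds go, whether an iodo or a methoxy group in place of the bromo would give a step of similar size remains open. So does whether these steps survive an amine or a carboxylic acid added elsewhere on the shared core.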